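Shifting the Trifluoromethyl Group on Two Different Cores

A few compounds are considered here, and "the series" means these few. Any claim that something is new, unique, unknown or untested is made for them only; others in the source may bear on it.

Compound 1 `Oc1ccccc1-c1cc(-c2ccccc2C(F)(F)F)cc(-c2ccccc2O)n1` and compound 2 `Oc1ccccc1-c1cc(-c2cccc(C(F)(F)F)c2)cc(-c2ccccc2O)n1` share one core. In a functional assay on DU-145 cells (Homo sapiens) for inhibition (a higher number here means a weaker inhibitor, a lower number a stronger inhibitor), compound 1 gives 4770 nM. For compound 2 the assay reports only a limit, > 50000 nM, (the limit of > 50000 nM in this assay, at which 1 of the 3 values shown sits). The change 3-(trifluoromethyl)phenyl in place of 2-(trifluoromethyl)phenyl on an aromatic carbon thus made an at least 10-fold higher number from compound 1 to compound 2 (1.02 log units; beyond the scatter). Compound 3 `Oc1ccc(-c2cc(-c3ccccc3C(F)(F)F)cc(-c3cccc(O)c3)n2)cc1` rests on a second core; the difference between the two cores is not broken down here. In this assay compound 3 gives 2750 nM. Compound 4 `Oc1ccc(-c2cc(-c3cccc(C(F)(F)F)c3)cc(-c3cccc(O)c3)n2)cc1` arises from compound 3 by the same kind of change, (3-(trifluoromethyl)phenyl in place of 2-(trifluoromethyl)phenyl on an aromatic carbon), though here the place is meta to a 3-hydroxyphenyl group and a 4-hydroxyphenyl group rather than to two 2-hydroxyphenyl groups. A step of similar size, an 11-fold higher number from compound 3 to compound 4 (1.04 log units; beyond the scatter), is expected, resting on an at least 10-fold higher number from compound 1 to compound 2 (1.02 log units; beyond the scatter). Compound 4 is therefore estimated at 30000 nM, between 8000 nM and 90000 nM.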

Compound 4, half-maximal inhibitory concentration: 11100 nM
Beside the measured number, compound 4's estimate is 2.7-fold (0.43 log units) above it; measured number inside the range.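

On the second core the change points the same way as on the first, with a 4.0-fold higher number from compound 3 to compound 4 (0.61 log units; beyond the scatter) in this assay, so on both cores shown the 3-(trifluoromethyl)phenyl compound is the weaker inhibitor. The value of compound 2, > 50000 nM, is a limit and not a number, so only the direction can be said to carry over, and two cores show no general rule. Whether the size of the step also carries over remains unsettled: the same change on two cores in this assay, an at least 10-fold higher number (1.02 log units; beyond the scatter) from compound 1 to compound 2 and a 4.0-fold higher number (0.61 log units; beyond the scatter) from compound 3 to compound 4; the limit leaves it open whether they differ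

The compounds shown leave open how the step would run on any other core. They also leave open whether a nitrile, a methyl group or an amine in place of the trifluoromethyl group would give a step of the same direction.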